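This account rests on a few compounds, and the source may have more. Where it says the series, first, only, none or still open, it means among the compounds named here.

Measured in a functional assay on A2780 cells (Homo sapiens) for antiproliferative activity, read by MTT assay, with a stated time of 48 h; a higher number here means a weaker inhibitor, a lower number a stronger inhibitor:
Compound 1 `COc1ccc2c(/C=C/C(=O)c3cc(OC)c(OC)c([N+](=O)[O-])c3)c[nH]c2c1`: 742 nM
Compound 2 `COc1cc(C(=O)/C=C/c2c[nH]c3ccccc23)cc([N+](=O)[O-])c1OC`: 1280 nM
Compound 3 `COc1cc(C(=O)/C=C/c2cn(C)c3ccccc23)cc([N+](=O)[O-])c1OC`: 1890 nM

Compound 2 (1280 nM) falls numerically between the other two compounds and lies within the scatter of each. The next compound to test is compound 4 `COc1cc(C(=O)/C=C/c2c[nH]c3ccccc23)cc(N)c1OC`, which has amino in place of nitro on an aromatic carbon. That carbon is ortho to a methoxy group.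

For the measured compounds named here, only two measured steps connect to compound 2. One is a 1.7-fold higher number from compound 1 to compound 2 (0.24 log units; within the scatter) with hydrogen in place of methoxy on an aromatic carbon. The other is a 1.5-fold higher number from compound 2 to compound 3 (0.17 log units; within the scatter) with methyl in place of hydrogen on an aromatic nitrogen. Both are small, but neither touches the nitro group, so they offer only weak guidance on this swap. No step beyond the scatter is therefore expected, and no direction can be favoured, although the uncertainty remains wide.

The estimate for compound 4 is 1000 nM in this assay, with an expected range from 200 nM to 5000 nM for a measurement. This estimate means an expected 1.3-fold lower number from compound 2 to compound 4 (0.11 log units; within the scatter) overall.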

Compound 4, half-maximal inhibitory concentration: 351 nM
The estimate for compound 4 lay 2.8-fold (0.45 log units) above the measured number; the range from low to high includes it.
By their numbers in this assay, from the lowest: compound 4; then compounds 1, 2 and 3 (each within the scatter of the next, the first and the last beyond it).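

In this assay, amino in place of nitro on this aromatic carbon, ortho to a methoxy group, gives a 3.6-fold lower number from compound 2 to compound 4 (0.56 log units; beyond the scatter) and is the only step shown that lies beyond the scatter. The two earlier steps changed other places and kept the nitro group, so they gave no sign that this position could shift the number by more than the scatter. The change removes three heavy atoms, brings in one, and adds one hydrogen-bond donor, but no measurement shown separates these differences or explains the step.

The compounds shown leave open whether a hydroxyl, a methylamino or an acetamide group on this carbon would behave like amino. They also leave open whether the same swap would give a similar step in compound 1 or compound 3.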